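This account rests on a few compounds, and the source may have more. Where it says the series, first, only, none or still open, it means among the compounds named here.

Compound 1 `Cc1cccc(C)c1-c1cccc(COc2ccc(CCC(=O)O)cn2)c1` gives 38 nM in a functional assay on CHO cells for agonist activity at Free fatty acid receptor 1 (Rattus norvegicus), read by calcium flux; a higher number here means that more compound is needed for the effect, a lower number that less compound is needed.
Compound 2 `Cc1cccc(C)c1-c1cccc(COc2ccc(CCC(=O)O)nc2)c1` gives 210 nM in this assay.
Compound 3 `Cc1cccc(C)c1-c1cccc(COc2ccc(CC(C)C(=O)O)cn2)c1` gives 2100 nM in this assay.

Compound 3 has the highest number of the three, so it needs the most compound for the effect; compound 2 comes nearest to it and compound 1 is furthest away. Going by the values given here, the one step that leads to compound 3 is a 55-fold higher number from compound 1 to compound 3 (1.74 log units; beyond the scatter), and it shows that attaching a methyl at that place on the chain costs a great deal.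

Compound 4 `Cc1cccc(C)c1-c1cccc(COc2ccc(C(C)CC(=O)O)cn2)c1` keeps the same atoms as compound 3 but rearranges the chain: 1-(carboxymethyl)ethyl in place of 2-carboxypropyl on an aromatic carbon. The methyl thus moves along the chain, away from the carbonyl carbon. Among the compounds with values here, only the step from compound 1 to compound 3 bears on this at all, and it tells of a methyl at a different place; no measured pair shows the effect of moving the methyl. Since the chain without any methyl, in compound 1, gives 38 nM, and the methyl in compound 3 gives 2100 nM, compound 4 is expected to fall between these, closer to compound 3, with a wide range. In this assay compound 4 is expected to give about 700 nM (range 150 nM to 3500 nM), which is an expected step of a 3.0-fold lower number from compound 3 to compound 4 (0.48 log units; beyond the scatter).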

Compound 4, half-maximal effective concentration: 320 nM
The estimate for compound 4 lay 2.2-fold (0.34 log units) above the measured number; low and high end bracket the measured number.
By their numbers in this assay, from the lowest: compound 1; then compounds 2 and 4 (each within the scatter of the next); then compound 3.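

In this assay, moving the methyl along the chain gives a 6.6-fold lower number from compound 3 to compound 4 (0.82 log units; beyond the scatter) and so shows that the cost of this methyl depends on which chain carbon carries it: on this aromatic carbon, 1-(carboxymethyl)ethyl is tolerated much better than 2-carboxypropyl. The methyl is still not free at its new place, as the comparison with the unbranched chain gives an 8.4-fold higher number from compound 1 to compound 4 (0.93 log units; beyond the scatter) and so neither branched chain matches the chain without a methyl. Nothing at hand explains why the place of the methyl matters so much.

The compounds shown leave open how other groups on the same chain carbon would fare, such as an ethyl, a second methyl or a fluorine, and whether a cyclopropane ring built into the chain would follow the methyl of compound 4. They also leave open whether the two mirror-image forms of the branched chain in compound 4 behave alike, and whether a methyl at this place has the same cost on the core of compound 2.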